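A few compounds are considered here, and "the series" means these few. Any claim that something is new, unique, unknown or untested is made for them only; others in the source may bear on it.

Measured so far:
compound 1 `O=C(COc1ccc(C(=O)/C=C/c2ccccc2Cl)cc1)N[C@H]1CCOC1=O` — in a functional assay on DU-145 cells (Homo sapiens) for antiproliferative activity, read by MTT assay, with a stated time of 72 h (a lower number here means a stronger inhibitor, a higher number a weaker inhibitor), compound 1 gives 3240 nM.
compound 2 `O=C1OCC[C@@H]1NC(=S)SCCOc1ccccc1Cc1ccccc1` — in this assay compound 2 gives > 64000 nM, which is a limit of the assay and not a number.

Compound 2 therefore stands at the limit of > 64000 nM in this assay, at which 1 of the 2 values shown sits, and nothing more precise can be said about where it lies. Within the data shown here, compound 1 is the only one of the pair with a number. Compound 3 `CCOc1ccccc1OCCSC(=S)N[C@H]1CCOC1=O` has not yet been tested in this assay. It differs from compound 2 in one place: ethoxy in place of benzyl on an aromatic carbon. Among the measured compounds shown here, no step between two measured compounds is available to set the size of this change. With compound 2 at a limit, the step that the limit leaves unreadable from compound 2 to compound 3 is expected to be none beyond the scatter, and compound 3 is expected to stay near that limit. The estimate for compound 3 in this assay is 80000 nM, with a range from 20000 nM to 300000 nM.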

Compound 3, half-maximal inhibitory concentration: 28300 nM
Estimate against measurement, compound 3: 2.8-fold (0.45 log units) above, and the stated range covers the measured number.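

In this assay, ethoxy in place of benzyl on an aromatic carbon, ortho to a large group, gives an at least 2.2-fold lower number from compound 2 to compound 3 (0.35 log units; beyond the scatter), so this position responds to the group it carries, which compound 2 alone could not show. The size of this step is only a bound, since the value of compound 2 is a limit of the assay and not a number: the limit of > 64000 nM in this assay, at which 1 of the 3 values shown sits. Compound 3 gives this part of the series a measured number, against which other groups at this place can be read.

This single pair cannot separate the loss of the benzyl ring from the arrival of the ethoxy oxygen, and a plain ethyl or a methoxy at this place would bear on that. From the compounds shown here alone, how an amine or a longer alkoxy chain would read in this assay also stays open.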